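Adding an Isobutyl Group to a Brominated Sulfonamide

This account rests on a few compounds, and the source may have more. Where it says the series, first, only, none or still open, it means among the compounds named here.

Measured compounds:
Compound 1 `Cc1ccc(S(=O)(=O)N2CCC(Cl)CC2)cc1` gives > 100000 nM in a functional assay on A2780 cells (Homo sapiens) for antiproliferative activity, read by sulforhodamine B assay, with a stated time of 48 h (on this read-out higher numbers stand for weaker inhibition of growth and lower numbers for stronger inhibition of growth), which is a limit of the assay.
Compound 2 `Cc1ccc(S(=O)(=O)N2CC[C@@H](Cl)C[C@@H]2CC(C)C)cc1` gives 36000 nM in this assay.
Compound 3 `Cc1ccc(S(=O)(=O)N2CCC(Br)CC2)cc1` gives > 100000 nM in this assay, again a limit of the assay.

Compound 3 therefore stands at the limit, the place where most values shown sit (the limit of > 100000 nM in this assay, at which 2 of the 3 values shown sit). Because a step that the two limits leave unreadable from compound 1 to compound 3 runs between two limits, its size is not readable, so the bromo and chloro analogues cannot be ranked against each other.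

Compound 4 `Cc1ccc(S(=O)(=O)N2CC[C@@H](Br)C[C@@H]2CC(C)C)cc1` differs from compound 3 by isobutyl in place of hydrogen on a saturated ring carbon. Within the data shown here, the one measured step that bears on this change is an at least 2.7-fold lower number from compound 1 to compound 2 (0.44 log units; beyond the scatter), where the same isobutyl group was added to the chloro analogue and the value moved from a limit to a number. A step of similar direction and at least modest size is expected here, an at least 2.5-fold lower number from compound 3 to compound 4 (0.39 log units; beyond the scatter).

Compound 4 is estimated at 40000 nM in this assay, with a range of 15000 nM to 150000 nM, while a limit instead of a number remains possible.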

Compound 4, concentration for 50% growth inhibition: 39000 nM
The estimate for compound 4 lay 1.0-fold (0.01 log units) above the measured number; the measured number falls inside the stated range.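

Compound 4 gives the isobutyl change a second case: on the bromo compound, it again turns a limit into a number, with an at least 2.5-fold lower number from compound 3 to compound 4 (0.40 log units; beyond the scatter). Among these compounds, it also makes bromo and chloro comparable for the first time, as both isobutyl compounds carry numbers in this assay, and the step is a 1.1-fold higher number from compound 2 to compound 4 (0.03 log units; within the scatter), so these two compounds do not separate. The change therefore points the same way on both cores shown: the same change on two cores in this assay, an at least 2.7-fold lower number (0.44 log units; beyond the scatter) from compound 1 to compound 2 and an at least 2.5-fold lower number (0.40 log units; beyond the scatter) from compound 3 to compound 4; the limit leaves it open whether they differ.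

As far as these compounds go, what a longer chain or an amine would do on this saturated ring carbon remains open. From the compounds shown here alone, the full size of both isobutyl steps also remains open, as compound 1 and compound 3 each stand at a limit: the limit of > 100000 nM in this assay, at which 2 of the 4 values shown sit.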